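Methylamino Pyrazine in Place of the Oxide Ring

The compounds below may be only part of what the source reports. "The series", "measured", "known", "first", "only" and "open" are said of these compounds alone.

Compound 1 `COc1ccnc(-c2cc(Cl)ccc2NS(=O)(=O)c2ccc(C(C)(C)C)cc2)c1`: 2500 nM
Compound 2 `CC(C)(C)c1ccc(S(=O)(=O)Nc2ccc(Cl)cc2-c2c(O)ccc[n+]2[O-])cc1`: 491 nM
Compound 3 `CNc1ncc(O)c(-c2cc(Cl)ccc2NS(=O)(=O)c2ccc(C(C)(C)C)cc2)n1`: 27 nM

All three numbers come from a functional assay on isolated protein for antagonist activity at C-C chemokine receptor type 9 (Homo sapiens), read by calcium flux, with a stated time of 10 min; a lower number here means a stronger inhibitor, a higher number a weaker inhibitor. Compound 2 sits second highest of the three: a 5.1-fold lower number from compound 1 to compound 2 (0.71 log units; beyond the scatter), while an 18-fold lower number from compound 2 to compound 3 (1.26 log units; beyond the scatter). Compound 4 `CNc1nccnc1-c1cc(Cl)ccc1NS(=O)(=O)c1ccc(C(C)(C)C)cc1` has not been measured; it differs from compound 2 by a group of 8 heavy atoms (5 carbon, 3 nitrogen; one six-membered aromatic ring with 2 hetero atoms) in place of a group of 8 heavy atoms (5 carbon, 1 nitrogen, 2 oxygen; one six-membered aromatic ring with 1 hetero atom), on an aromatic carbon. The step that bears most on this change runs from compound 2 to compound 3, where a ring carrying a methylamino group brought a large drop, an 18-fold lower number from compound 2 to compound 3 (1.26 log units; beyond the scatter). Compound 4 shares that methylamino group with compound 3 but not the rest of its ring, so a drop smaller than that one is expected. The expected step is a 4.9-fold lower number from compound 2 to compound 4 (0.69 log units; beyond the scatter). Compound 4 is therefore estimated at 100 nM, within 25 nM to 400 nM.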

Compound 4, half-maximal inhibitory concentration: 25 nM
For compound 4 the middle estimate is 4.0-fold (0.60 log units) above the measured one; low and high end bracket the measured number.
By their numbers in this assay, from the lowest: compounds 4 and 3 (each within the scatter of the next); then compound 2; then compound 1.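

On this aromatic carbon, the 3-(methylamino)pyrazin-2-yl group outperforms both other groups in this assay (a 20-fold lower number from compound 2 to compound 4 (1.29 log units; beyond the scatter); a 100-fold lower number from compound 1 to compound 4 (2.00 log units; beyond the scatter)). It matches the ring of compound 3 (a 1.1-fold lower number from compound 3 to compound 4 (0.03 log units; within the scatter)), so the extra oxygen of that ring is not needed to reach this level in this assay. The methylamino group is therefore paired here with two different rings that give values within the scatter of each other.

On these data alone, how much depends on the methylamino group itself remains open, and an amino or dimethylamino group in its place would test this. Nothing shown here gives a reason for these steps.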